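The source may report more compounds than this note shows. Statements on the series, on what has been measured and on what is new or still open speak of the compounds shown alone.

Working notes on the series. In a functional assay on HL-60 cells (Homo sapiens) for inhibition, read by MTT assay, with a stated time of 48 h, tested at 10 uM (a lower number here means less inhibition of growth, a higher number more inhibition of growth at the concentration tested), compound 1 `Cc1cc(=O)c2c(O)cc(OCc3ccccc3)c([C@H]3CCN(C)C[C@H]3O)c2o1` gives 24%, compound 2 `COc1ccc(COc2cc(O)c3c(=O)cc(C)oc3c2[C@H]2CCN(C)C[C@H]2O)cc1` gives 23%, and compound 3 `CN1CC[C@H](c2c(O)cc(O)c3c(=O)cc(/C=C/c4cccc(Cl)c4)oc23)[C@H](O)C1` gives 35%, the highest of the three numbers and beyond the scatter of both others. Compound 4 `CN1CC[C@H](c2c(O)cc(O)c3c(=O)cc(/C=C/c4ccccc4Cl)oc23)[C@H](O)C1` is not yet measured. The change is 2-chlorophenyl in place of 3-chlorophenyl on a double-bonded chain carbon bound to a double-bonded chain carbon. Among the compounds with values here, the only measured step, a number 1 percentage points lower from compound 1 to compound 2 (within the scatter), is methoxy in place of hydrogen on an aromatic carbon, so it bears only weakly on this change. Within the data shown here, no measured step swaps one chlorophenyl for the other. The estimated step is a number 2 percentage points lower from compound 3 to compound 4 (within the scatter), and none beyond the scatter is expected. For compound 4 the expected value in this assay is 33%, with an estimated range of 20% to 46%.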

Compound 4, percent growth inhibition at one concentration: 61%
Estimate against measurement, compound 4: 28 percentage points below; measured number outside the range, above it.
By their numbers in this assay, from the lowest: compounds 2 and 1 (each within the scatter of the next); then compound 3; then compound 4.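

In this assay, 2-chlorophenyl in place of 3-chlorophenyl on a double-bonded chain carbon bound to a double-bonded chain carbon gives a number 26 percentage points higher from compound 3 to compound 4 (beyond the scatter). Within the data shown here, the only earlier step stayed within the scatter, so this is the first sign that the series responds to a change at one place, here with the same atoms joined differently. Nothing available accounts for the size of this step. Still open, from the compounds shown here alone, is whether bromine or an amine in place of the chlorine of 2-chlorophenyl would keep this higher number.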